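Benzyl versus phenyl on the triazole nitrogen

The source may hold more compounds than are shown below. What is called first, only, known or untested is meant among the compounds shown, and "the series" means these compounds.

Two members of this series carry measured numbers in an assay on membranes from brain for displacement of a labelled ligand from Sigma non-opioid intracellular receptor 1 (Cavia porcellus), read by scintillation counting, with a stated time of 90 min; on this read-out higher numbers stand for weaker inhibition and lower numbers for stronger inhibition. Compound 1 `COc1ccc(Cn2cc(C(=O)NCCCCN3CCc4cc(OC)c(OC)cc4C3)nn2)cc1` gives 3350 nM. Compound 2 `COc1cc2c(cc1OC)CN(CCNC(=O)c1cn(-c3ccccc3OC)nn1)CC2` gives 15500 nM, the higher of the two numbers, and the gap between them lies beyond the usual scatter. For the measured compounds named here, compound 1 and compound 2 differ in more than one place, so their two values show only that the pair sits well apart; no single structural step between them is defined.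

Compound 3 `COc1ccccc1Cn1cc(C(=O)NCCN2CCc3cc(OC)c(OC)cc3C2)nn1` is not yet measured. It is built from compound 2 by the change (2-methoxybenzyl in place of 2-methoxyphenyl on an aromatic nitrogen), that is, 2-methoxybenzyl in place of 2-methoxyphenyl on an aromatic nitrogen. Going by the values given here, with no measured step of the same kind, the expectation rests on the observation that the lower of the two numbers belongs to compound 1, whose aromatic nitrogen also carries a benzyl-type group. A moderate step downward is therefore expected for compound 3, of size a 2.2-fold lower number from compound 2 to compound 3 (0.35 log units; beyond the scatter). The estimate for compound 3 is 7000 nM, within a range of 2500 nM to 20000 nM.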

Compound 3, inhibition constant: 18600 nM
Estimate against measurement, compound 3: 2.7-fold (0.42 log units) below; the range from low to high includes it.
By their numbers in this assay, from the lowest: compound 1; then compounds 2 and 3 (each within the scatter of the next).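

In this assay, for the compounds shown here, 2-methoxybenzyl in place of 2-methoxyphenyl on the aromatic nitrogen gives a 1.2-fold higher number from compound 2 to compound 3 (0.08 log units; within the scatter), the first single-place step. At this position, the change therefore leaves the number within the scatter, and a benzyl-type group here gives no lower number on this pair. Compound 1 differs from compound 3 in more than one place, so what sets compound 1 apart remains unassigned, and nothing measured here gives a reason for the result.

Still open, from the compounds shown here alone, is whether the longer chain of compound 1, rather than the group on the aromatic nitrogen, goes with its lower number. Also open, going by these compounds, is how an unsubstituted benzyl or a pyridylmethyl group on this nitrogen would read in this assay.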